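Sulfonyl-side swap at the high end of the numbers

The source may report more compounds than this note shows. Statements on the series, on what has been measured and on what is new or still open speak of the compounds shown alone.

Among the measured compounds shown here, in a functional assay on DU-145 cells (Homo sapiens) for inhibition, read by trypan blue exclusion, with a stated time of 96 h (on this read-out higher numbers stand for weaker inhibition of growth and lower numbers for stronger inhibition of growth), compound 1 `CSc1ccc(/C=C(\C(=O)c2ccc(Br)cc2)S(=O)(=O)Cc2ccc(F)cc2)cc1` gives 50000 nM and stands at the high end of the three numbers so far. Compound 3 `COc1ccc(/C=C(\C(=O)c2ccc(Br)cc2)S(=O)(=O)Cc2ccc(F)cc2)cc1` gives 25000 nM and remains level with it, as a 2.0-fold lower number from compound 1 to compound 3 (0.30 log units; within the scatter) shows. Compound 2 `Cc1ccc(C)c(/C=C(\C(=O)c2ccc(Br)cc2)S(=O)(=O)Cc2ccc(F)cc2)c1` gives 1000 nM and stands well apart, with a 50-fold lower number from compound 1 to compound 2 (1.70 log units; beyond the scatter) on this read-out.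

Compound 4 `CSc1ccc(/C=C(\C(=O)c2ccc(Br)cc2)S(=O)(=O)c2ccc(C)cc2)cc1` differs from compound 1 by 4-methylphenyl in place of 4-fluorobenzyl on a sulfonyl sulfur and is otherwise the same. The measured steps, including a 25-fold higher number from compound 2 to compound 3 (1.40 log units; beyond the scatter) as the second large one, all change the group on the double-bonded chain carbon. None changes the group on the sulfonyl sulfur, so they range from within the scatter to large without giving a size or direction for this swap. No shift beyond the scatter is expected, and the estimated change is a 1.7-fold lower number from compound 1 to compound 4 (0.22 log units; within the scatter) with its direction uncertain. In this assay compound 4 is expected at 30000 nM with an estimated range of 6000 nM to 100000 nM as the working estimate.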

Compound 4, concentration for 50% growth inhibition: 1000 nM
For compound 4 the middle estimate is 30-fold (1.48 log units) above the measured one; measured number below the stated range.
By their numbers in this assay, from the lowest: compounds 2 and 4 (each within the scatter of the next); then compounds 3 and 1 (each within the scatter of the next).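

The group on the sulfonyl sulfur is not a silent position: in this assay the change from 4-fluorobenzyl to 4-methylphenyl gives a 50-fold lower number from compound 1 to compound 4 (1.70 log units; beyond the scatter) with the rest of the structure held fixed. Among the compounds shown here, earlier large steps all came from changes on the double-bonded chain carbon, so this is the first sign that the sulfonyl side can also move the number this far. Both groups carry one six-membered aromatic ring of carbon only and neither has a hydrogen-bond donor or acceptor, and no measurement at hand accounts for the step.

For the compounds shown here, the single swap changes both the link to the ring and the ring substituent, so the two remain unseparated; 4-fluorophenyl or 4-methylbenzyl on the sulfonyl sulfur would divide them. As far as these compounds go, whether 4-methylphenyl gives a similar step with the 2,5-dimethylphenyl or 4-methoxyphenyl group on the chain carbon also remains open.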